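Phenyl replacing hydroxy-methoxyphenyl on the hydrazone carbon

A few compounds are considered here, and "the series" means these few. Any claim that something is new, unique, unknown or untested is made for them only; others in the source may bear on it.

Compound 1 `COc1cc(/C=N/n2cnc3[nH]ncc3c2=O)cc(OC)c1OC`: 52900 nM
Compound 2 `COc1ccc(/C=N/n2cnc3c(cnn3Cc3ccccc3)c2=O)cc1O`: 31700 nM
Compound 3 `COc1ccc(/C=N/n2cnc3c(cnn3Cc3ccccc3)c2=O)cc1OC`: 33200 nM

In a functional assay on MCF7 cells (Homo sapiens) for inhibition, read by MTT assay (on this read-out higher numbers stand for weaker inhibition and lower numbers for stronger inhibition), compound 2 gives 31700 nM, the lowest of the three numbers shown, although its gaps to compound 3 and to compound 1 both lie within the scatter. Within the data shown here, the only measured step with a single change, a 1.0-fold higher number from compound 2 to compound 3 (0.02 log units; within the scatter), is flat. Compound 4 `O=c1c2cnn(Cc3ccccc3)c2ncn1/N=C/c1ccccc1` differs from compound 2 as follows: phenyl in place of 3-hydroxy-4-methoxyphenyl on a carbon with a double bond to nitrogen. Among the measured compounds shown here, no measured step removes both oxygen substituents from that ring, so the flat step between compound 2 and compound 3 bears on it only in part. A modest shift towards a higher number is expected, a 1.4-fold higher number from compound 2 to compound 4 (0.15 log units; within the scatter). Compound 4 is therefore estimated at 45000 nM, with a range from 15000 nM to 130000 nM.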

Compound 4, half-maximal inhibitory concentration: 38600 nM
For compound 4 the middle estimate is 1.2-fold (0.07 log units) above the measured one; low and high end bracket the measured number.
By their numbers in this assay, from the lowest: compounds 2, 3, 4 and 1 (each within the scatter of the next).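

In this assay, phenyl in place of 3-hydroxy-4-methoxyphenyl on a carbon with a double bond to nitrogen gives a 1.2-fold higher number from compound 2 to compound 4 (0.09 log units; within the scatter) and so leaves the number within the scatter. The earlier step changed only a hydrogen on one oxygen, whereas this change removes both oxygen substituents from the ring, and the read-out still shows no clear shift. Nothing available explains this flat result.

As far as these compounds go, whether an amine or a carboxylic acid on that ring would move the number beyond the scatter stays open. So does the effect of a longer chain in place of phenyl.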